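This account rests on a few compounds, and the source may have more. Where it says the series, first, only, none or still open, it means among the compounds named here.

Compound 1 `Cc1ccc(-c2cc(C(=O)N3CCC4(CC3)CC(=O)c3nn(C(C)(C)C)cc3O4)c3ccccc3n2)cc1` gives 1440 nM in a functional assay on HepG2 cells (Homo sapiens) for inhibition, read by MTT assay, with a stated time of 72 h; on this read-out lower numbers stand for stronger inhibition and higher numbers for weaker inhibition. Compound 2 `CC(C)(C)n1cc2c(n1)C(=O)CC1(CCN(C(=O)c3cc(-c4ccccc4Cl)nc4ccccc34)CC1)O2` returns only a limit in this assay, > 10000 nM. Compound 2 therefore sits at the limit of > 10000 nM in this assay, at which 1 of the 2 values shown sits, and the step of an at least 6.9-fold higher number from compound 1 to compound 2 (0.84 log units; beyond the scatter) is known only as a bound. Compound 3 `CN1CCN(c2cc(C(=O)N3CCC4(CC3)CC(=O)c3nn(C(C)(C)C)cc3O4)c3ccccc3n2)CC1` carries the change (4-methylpiperazin-1-yl in place of 2-chlorophenyl on an aromatic carbon). Among the compounds with values here, the sole measured step, an at least 6.9-fold higher number from compound 1 to compound 2 (0.84 log units; beyond the scatter), shows that the group on this carbon can shift the read-out beyond the scatter, but no measured pair places 4-methylpiperazin-1-yl against 2-chlorophenyl, so no direction is fixed. The step of an at least 1.2-fold lower number from compound 2 to compound 3 (0.09 log units; that floor lies within the scatter) is expected to be uncertain. Compound 3 is estimated at 8000 nM, range 1500 nM to 30000 nM.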

Compound 3, half-maximal inhibitory concentration: 9550 nM
Compound 3: the middle estimate sits 1.2-fold (0.08 log units) below what was measured, within the range that was stated.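

In this assay 4-methylpiperazin-1-yl in place of 4-methylphenyl on this carbon next to the ring nitrogen gives a 6.6-fold higher number from compound 1 to compound 3 (0.82 log units; beyond the scatter) as a step with a measured number at both ends. The loss against 4-methylphenyl is therefore not confined to 2-chlorophenyl, and it also appears with a non-aromatic ring with 2 hetero atoms. Against 2-chlorophenyl, 4-methylpiperazin-1-yl gives an at least 1.0-fold lower number from compound 2 to compound 3 (0.01 log units; that floor lies within the scatter) as a bound only, and this sets no order between the two groups. One end of this step is only a limit: the limit of > 10000 nM in this assay, at which 1 of the 3 values shown sits.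

Open, on these data alone, is whether any group on this carbon reads lower than 4-methylphenyl, for example a 4-methoxyphenyl group or a simple primary amine.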